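The source may hold more compounds than are shown below. What is called first, only, known or untested is meant among the compounds shown, and "the series" means these compounds.

Compound 1, `C/C=C/C=C/CCCCCCCCC[C@]1(OC)C=C[C@H](CC(=O)OC)OO1`, and compound 2, `CCCCCCCCCCCCCCCC[C@@]1(OC)C=C[C@@H](CC(=O)OC)OO1`, share one core and differ only in the long chain attached to it. In a functional assay on P388 cells (Mus musculus) for cytotoxicity, tested at 0.05 ug/mL (on this read-out higher numbers stand for more inhibition at the one concentration tested (going by the name of the read-out) and lower numbers for less inhibition), compound 1 gives 50%, and compound 2 gives 50%. Compound 1 thus stands level with compound 2 at the digits shown, inside the usual scatter of this measurement, so no order between the two can be claimed.

Compound 3, `C/C=C/C=C/CCCCCCC[C@]1(OC)C=C[C@H](CC(=O)OC)OO1`, has not yet been measured. It differs from compound 1 in one place: penta-1,3-dien-1-yl in place of hepta-3,5-dien-1-yl on a saturated chain carbon, seven bonds along the chain from a saturated ring carbon. The chain is shorter by the count given, while its two double bonds outside aromatic rings and the rest of the molecule stay as they are.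

Two chains of quite different length and unsaturation in compound 1 and compound 2 produced the same read-out, so a change in the chain is not expected to matter much here. The step of a number 5 percentage points lower from compound 1 to compound 3 (within the scatter) is estimated to be small, at most a slight drop that stays within the scatter. Compound 3 is expected to give about 45% in this assay, within the range 25% to 65%.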

Compound 3, a percentage reported as inhibition, at one concentration (the size of the read-out at that concentration, not a potency): 50%
For compound 3 the middle estimate is 5 percentage points below the measured one, and the stated range covers the measured number.
By their numbers in this assay, from the lowest: compounds 1, 2 and 3 (each within the scatter of the next).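

In this assay, putting penta-1,3-dien-1-yl in place of hepta-3,5-dien-1-yl on a saturated chain carbon, seven bonds along the chain from a saturated ring carbon, gives no change at the digits printed from compound 1 to compound 3 (within the scatter). This is the first pair shown that differs in one place only, so it isolates chain length: the shorter chain keeps both double bonds outside aromatic rings, and at this one concentration the read-out stays level, which suggests that this part of the chain can be shortened to this extent without a visible loss in this test. Nothing available here explains this result.

The compounds shown leave open how far the chain can be shortened before the read-out moves, and whether a much shorter chain, or a chain ending in a carboxylic acid or an amine, would hold this level. Going by these compounds, because a single-concentration percentage is not a potency, it also remains open whether compound 1 and compound 3 would separate across a range of concentrations.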